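The source may report more compounds than this note shows. Statements on the series, on what has been measured and on what is new or still open speak of the compounds shown alone.

Measured compounds, with the value each gives in the assay:

compound 1 `Nc1nc2cc(-c3nn(CCCCCCCCCC(=O)NO)c4ncnc(N)c34)ccc2o1` — a limit only, > 50000 nM
compound 2 `Nc1nc2cc(-c3nn(CC(=O)NO)c4ncnc(N)c34)ccc2o1` — a limit only, > 150000 nM
compound 3 `Nc1nc2cc(-c3nn(CCCC(=O)NO)c4ncnc(N)c34)ccc2o1` — a limit only, > 150000 nM

In a functional assay on HeLa cells (Homo sapiens) for inhibition, read by MTT assay, with a stated time of 72 h (a lower number here means a stronger inhibitor, a higher number a weaker inhibitor), compound 3 gives only a limit, > 150000 nM. Among the compounds with values here, two of the three values sit at the limit of > 150000 nM in this assay, at which 2 of the 3 values shown sit, and one at the limit of > 50000 nM in this assay, at which 1 of the 3 values shown sits, so no compound has yet given a number. The two steps that lead into compound 3 are a step that the two limits leave unreadable from compound 1 to compound 3 and a step that the two limits leave unreadable from compound 2 to compound 3; both join limits and their size cannot be read.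

Compound 4 `Nc1nc2cc(-c3nn(CCC(=O)NO)c4ncnc(N)c34)ccc2o1` is not yet measured. Against compound 3 the change is hydroxycarbamoyl in place of (hydroxycarbamoyl)methyl on a saturated chain carbon, two bonds along the chain from an aromatic nitrogen. The same kind of cut, one bond further out, lies within the measured set as the steps into compound 3, and neither gave a readable size. Within the data shown here, there is thus no measured step that points to a direction here, and the expectation rests only on the fact that every neighbour sits at a limit.

The step from compound 3 to compound 4 is estimated as a step that the limit leaves unreadable from compound 3 to compound 4, that is, no readable change. Compound 4 is expected to give 200000 nM in this assay, within 40000 nM to 1000000 nM, most likely again reported only as a limit.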

Compound 4, half-maximal inhibitory concentration: > 150000 nM
Compound 4: no number, only a limit (the forecaster's own chance of this, stated with the estimate: 85%); the middle value is on the limit's open side.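

In this assay compound 4 gives > 150000 nM, a limit and not a number. The steps joining compound 4 to compound 1, compound 2 and compound 3 all link limits, and their size cannot be read. On these data alone, whether chain length affects the read-out in any way remains open, with no number from any of the four compounds.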